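Swapping an aromatic ring for a butyl chain

This account rests on a few compounds, and the source may have more. Where it says the series, first, only, none or still open, it means among the compounds named here.

Compound 1 `CCCCCCc1cn(CCCN2C(=O)COc3ccccc32)nn1`: 1100 nM
Compound 2 `O=C1COc2ccccc2N1CCCn1cc(-c2cccnc2)nn1`: 3000 nM

Among the measured compounds shown here, in a functional assay on MDA-MB-231 cells (Homo sapiens) for antiproliferative activity, read by sulforhodamine B assay, with a stated time of 48 h (a higher number here means a weaker inhibitor of growth, a lower number a stronger inhibitor of growth), compound 2 gives 3000 nM, the higher of the two numbers so far, while compound 1 gives 1100 nM. The next compound, compound 3 `CCCCc1cn(CCCN2C(=O)COc3ccccc32)nn1`, puts butyl in place of pyridin-3-yl on an aromatic carbon of the five-membered aromatic ring with 3 nitrogen (butyl in place of pyridin-3-yl on an aromatic carbon). For the measured compounds named here, only one measured step bears on this change: a 2.7-fold higher number from compound 1 to compound 2 (0.44 log units; beyond the scatter), a modest move that brought in the same pyridin-3-yl, there in place of hexyl. Butyl, like hexyl, has no ring, so going back to a chain should lower the number in this assay, by a similar or somewhat smaller amount. Going by the values given here, no butyl compound has been measured, so this remains uncertain. The expected change is a 2.0-fold lower number from compound 2 to compound 3 (0.30 log units; within the scatter). For compound 3 the estimated value is 1500 nM, with an expected range from 600 nM to 3500 nM.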

Compound 3, concentration for 50% growth inhibition: 3600 nM
Beside the measured number, compound 3's estimate is 2.4-fold (0.38 log units) below it, outside the stated range (above it).
By their numbers in this assay, from the lowest: compound 1; then compounds 2 and 3 (each within the scatter of the next).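

In this assay, putting butyl in place of pyridin-3-yl on this aromatic carbon gives a 1.2-fold higher number from compound 2 to compound 3 (0.08 log units; within the scatter) and so does not separate the two groups. Chain length does matter at this position: going from hexyl to butyl gives a 3.3-fold higher number from compound 1 to compound 3 (0.51 log units; beyond the scatter) and leaves the shorter chain level with the pyridin-3-yl compound, so the presence of a ring alone does not set compound 2 apart from compound 1. No available data explain either result.

On these data alone, with only these three compounds, it remains open whether a longer chain such as octyl would bring the number lower than hexyl does. As far as these compounds go, it is also open how a plain phenyl ring or a chain ending in an amine would compare at this position.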